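Dropping the Methoxy Group: an Estimate for Compound 4

The source may report more compounds than this note shows. Statements on the series, on what has been measured and on what is new or still open speak of the compounds shown alone.

Three compounds were measured in a functional assay on T47D cells (Homo sapiens) for inhibition, read by sulforhodamine B assay, with a stated time of 48 h; on this read-out lower numbers stand for stronger inhibition of growth and higher numbers for weaker inhibition of growth:
compound 1 `CC(=O)/C(=C\c1c(-c2ccccc2)[nH]c2ccccc12)S(=O)(=O)c1ccccc1`: 1400 nM
compound 2 `O=C(/C(=C\c1c(-c2ccccc2)[nH]c2ccccc12)S(=O)(=O)c1ccccc1)c1ccccc1`: 3400 nM
compound 3 `COc1ccc2[nH]c(-c3ccccc3)c(/C=C(\C#N)S(=O)(=O)c3ccccc3)c2c1`: 5200 nM

Compound 3 shows the highest of the three numbers; compound 2 sits within the scatter of it, whereas compound 1 lies beyond the scatter below it. Compound 4 `N#C/C(=C\c1c(-c2ccccc2)[nH]c2ccccc12)S(=O)(=O)c1ccccc1` differs from compound 3 by hydrogen in place of methoxy on an aromatic carbon. Among the compounds with values here, the only measured step, a 2.4-fold higher number from compound 1 to compound 2 (0.39 log units; beyond the scatter), changes the group on the carbonyl carbon, not the aromatic ring, so no measured step bears on this change. Compounds 1 and 2 carry the same unsubstituted ring as compound 4, and their values show that this core gives numbers in the same broad region. Within the data shown here, with no directly relevant step, compound 4 is expected to stay close to compound 3, at 3500 nM, within 1200 nM to 10000 nM, a step of a 1.5-fold lower number from compound 3 to compound 4 (0.17 log units; within the scatter).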

Compound 4, concentration for 50% growth inhibition: 3800 nM
Estimate against measurement, compound 4: 1.1-fold (0.04 log units) below, and the stated range covers the measured number.
By their numbers in this assay, from the lowest: compound 1; then compounds 2, 4 and 3 (each within the scatter of the next).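

Hydrogen in place of methoxy on this aromatic carbon gives a 1.4-fold lower number from compound 3 to compound 4 (0.14 log units; within the scatter), so the two compounds cannot be told apart here. On the chain carbon, cyano in place of benzoyl gives a 1.1-fold higher number from compound 2 to compound 4 (0.05 log units; within the scatter), again no separation, whereas cyano in place of acetyl gives a 2.7-fold higher number from compound 1 to compound 4 (0.43 log units; beyond the scatter), a modest step beyond the scatter. Nothing available gives a reason for these steps.

From the compounds shown here alone, whether an amine or a carboxylic acid on this aromatic carbon would read like hydrogen and methoxy stays open. So does how a longer chain on the carbonyl carbon would read.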